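Swapping hydroxy for bromo on compound 3

The source may report more compounds than this note shows. Statements on the series, on what has been measured and on what is new or still open speak of the compounds shown alone.

Three compounds have been measured so far in a functional assay on MCF7 cells (Homo sapiens) for inhibition, read by MTT assay, with a stated time of 72 h (on this read-out higher numbers stand for weaker inhibition and lower numbers for stronger inhibition), with these results:

Compound 1 `COc1cc(OC)c(OC)cc1/C=C/C(=O)c1cc(Cl)ccc1O` gives > 150000 nM as a limit
Compound 2 `COc1cc(OC)c(OC)cc1/C=C/C(=O)c1ccc(F)cc1` gives 30000 nM as a number
Compound 3 `COc1cc(OC)c(OC)cc1/C=C/C(=O)c1ccc(O)cc1` gives 182000 nM as a number

Compound 1 shows > 150000 nM as a limit of the assay and not as a number. Of the two true numbers, compound 3 at 182000 nM is the higher, which means weaker inhibition than compound 2 shows at 30000 nM in this pair. From the compounds shown here alone, the remaining comparison is a step that the limit leaves unreadable from compound 1 to compound 3 and stays open.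

Compound 4 `COc1cc(OC)c(OC)cc1/C=C/C(=O)c1ccc(Br)cc1` has bromo in place of hydroxy on an aromatic carbon, para to a large group, counted as bromo in place of hydroxy on an aromatic carbon with the rest of the structure unchanged. The closest measured guide is a 6.1-fold higher number from compound 2 to compound 3 (0.78 log units; beyond the scatter) for fluoro giving way to hydroxy at that same place. A second step of an at least 5.0-fold lower number from compound 1 to compound 2 (0.69 log units; beyond the scatter) replaces the whole 5-chloro-2-hydroxyphenyl group and bears on this less directly.

For the measured compounds named here, no bromo compound has been measured, so the expectation rests on bromo acting more like the fluoro of compound 2 at 30000 nM than like hydroxy. A modest fall is therefore expected, estimated as a 5.2-fold lower number from compound 3 to compound 4 (0.72 log units; beyond the scatter) in this assay with real doubt about its size. The estimate for compound 4 is 35000 nM expected within 11000 nM to 110000 nM and no tighter.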

Compound 4, half-maximal inhibitory concentration: 18300 nM
For compound 4 the middle estimate is 1.9-fold (0.28 log units) above the measured one; the range from low to high includes it.
By their numbers in this assay, from the lowest: compounds 4 and 2 (each within the scatter of the next); then compound 3.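

In this assay, the change from 4-hydroxyphenyl to 4-bromophenyl gives a 9.9-fold lower number from compound 3 to compound 4 (1.00 log units; beyond the scatter) and so shows that hydroxy is not the only replacement at this place on the ring to go with a clearly lower number than compound 3 gives; fluoro had shown this once, and bromo now shows it a second time. Fluoro and bromo are not separated by this read-out, with a 1.6-fold lower number from compound 2 to compound 4 (0.21 log units; within the scatter) so that compound 2 and compound 4 sit together, while compound 3 stands apart from both. Replacing the whole ring group gives an at least 8.1-fold lower number from compound 1 to compound 4 (0.91 log units; beyond the scatter) and this tells only a minimum size for that step, since it rests on a limit: the limit of > 150000 nM in this assay, at which 1 of the 4 values shown sits.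

The compounds shown carry only hydroxy, fluoro or bromo at this place, so whether an amine, a nitrile or a carboxylic acid there would fall with the two halogens or with hydroxy stays open. Also open, from the compounds shown here alone, is which part of the 5-chloro-2-hydroxyphenyl group of compound 1 matters, as the steps from that compound change more than one thing at once.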